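The source may report more compounds than this note shows. Statements on the series, on what has been measured and on what is new or still open speak of the compounds shown alone.

Compound 1 `CCC1(S(=O)(=O)NC(=O)[C@@]23C[C@H]2/C=C\CCCCN(C)C(=O)N[C@@H](CCOc2cc(-c4nc(C(C)C)cs4)nc4c(Cl)c(OC)ccc24)C(=O)N3)CC1` gives 49300 nM in an ADME assay on cells (Homo sapiens) for activation (on this read-out lower numbers stand for higher toxicity in this test and higher numbers for lower toxicity in this test), the highest of the two numbers shown. Compound 2 `COc1ccc2c(OCC[C@@H]3NC(=O)N(C)CCCC/C=C\[C@@H]4C[C@@]4(C(=O)NS(=O)(=O)C4(C)CC4)NC3=O)cc(-n3ccc(C(C)C)n3)nc2c1C` gives 25600 nM in this assay, a gap that lies within the usual scatter, so the two cannot be placed in order. Compound 3 `COc1ccc2c(OCC[C@@H]3NC(=O)N(C)CCCC/C=C\[C@@H]4C[C@@]4(C(=O)NS(=O)(=O)C4CC4)NC3=O)cc(-c3nc(C(C)C)cs3)nc2c1F` reaches only a limit of this assay, > 75000 nM. One of the three values shown sits at such a limit (the limit of > 75000 nM in this assay, at which 1 of the 3 values shown sits). Compound 4 `COc1ccc2c(OCC[C@@H]3NC(=O)N(C)CCCC/C=C\[C@@H]4C[C@@]4(C(=O)NS(=O)(=O)N4CCC[C@H]4C#N)NC3=O)cc(-c3nc(C(C)C)cs3)nc2c1Cl` has not yet been measured; it differs from compound 1 in one place: 2-cyanopyrrolidin-1-yl in place of 1-ethylcyclopropyl on a sulfonyl sulfur. Within the data shown here, no measured pair isolates this change, so the step is expected to be a 1.1-fold lower number from compound 1 to compound 4 (0.04 log units; within the scatter), not beyond the scatter in either direction. Compound 4 is therefore estimated at 45000 nM, within 20000 nM to 75000 nM.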

Compound 4, half-maximal cytotoxic concentration: 28300 nM
Estimate against measurement, compound 4: 1.6-fold (0.20 log units) above; low and high end bracket the measured number.
By their numbers in this assay, from the lowest: compounds 2, 4 and 1 (each within the scatter of the next). At a limit, above all of these: compound 3.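

Compound 4 shows that the sulfonyl sulfur can carry a nitrogen-linked ring bearing a nitrile: in this assay, 2-cyanopyrrolidin-1-yl in place of 1-ethylcyclopropyl gives a 1.7-fold lower number from compound 1 to compound 4 (0.24 log units; within the scatter). Among these compounds, this is the first single-place comparison at this position, and no readable shift appears in the toxicity read-out. Nothing shown accounts for the size of this step.

Open, from the compounds shown here alone, is whether the ring or the nitrile matters more, which plain pyrrolidin-1-yl on the same sulfur would help separate. Also open, going by these compounds, is how a carboxylic acid or a primary amine would behave there.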